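The source may hold more compounds than are shown below. What is called first, only, known or untested is meant among the compounds shown, and "the series" means these compounds.

Measured so far in a functional assay on HeLa cells (Homo sapiens) for cytotoxicity, read by MTT assay, with a stated time of 72 h; a higher number here means a weaker inhibitor, a lower number a stronger inhibitor:

compound 1 `COC(=O)c1sc2cc(C)ccc2c1Nc1cc(OC)c(OC)c(OC)c1`: 0.31 nM
compound 2 `COC(=O)c1sc2ncccc2c1Nc1cc(OC)c(OC)c(OC)c1`: 342 nM
compound 3 `CCOC(=O)c1sc2cc(C)ccc2c1Nc1cc(OC)c(OC)c(OC)c1`: 0.38 nM

Compound 1 and compound 3 share a core, and the numbers for the two lie within the scatter of each other. The number for compound 2 is the highest of the three, and it differs from both compound 1 and compound 3 by far more than the scatter. The difference between the core of compound 1 and the core of compound 2 is not broken down here.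

Compound 4 `CCOC(=O)c1sc2ncccc2c1Nc1cc(OC)c(OC)c(OC)c1` is not yet measured in this assay. It stands to compound 2 as compound 3 stands to compound 1: methyl in place of hydrogen on a saturated chain carbon bound to an oxygen next to a carbonyl group. The same change, (methyl in place of hydrogen on a saturated chain carbon bound to an oxygen next to a carbonyl group), gave a 1.2-fold higher number from compound 1 to compound 3 (0.09 log units; within the scatter). The two place descriptions agree word for word, so this is the same change made on a different core.

Compound 4 is expected near compound 2, because the measured step of a 1.2-fold higher number from compound 1 to compound 3 (0.09 log units; within the scatter) stayed within the scatter. The expected step is a 1.2-fold higher number from compound 2 to compound 4 (0.07 log units; within the scatter). Compound 4 is estimated at 400 nM, with a likely range from 200 nM to 900 nM.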

Compound 4, half-maximal inhibitory concentration: 2100 nM
Compound 4: middle estimate off by 5.3-fold (0.72 log units), on the low side; the measured number lies above the stated range.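

In this assay, the change from methoxycarbonyl to ethoxycarbonyl gives a 6.1-fold higher number from compound 2 to compound 4 (0.79 log units; beyond the scatter). The size of this change differs between the two cores, so on this evidence a step measured on one core cannot simply be carried to the other: the same change on two cores in this assay, a 1.2-fold higher number (0.09 log units; within the scatter) from compound 1 to compound 3 and a 6.1-fold higher number (0.79 log units; beyond the scatter) from compound 2 to compound 4, 5.0-fold (0.70 log units) apart, beyond the scatter of two such steps

Among these compounds, this rests on just two pairs of compounds, and it shows only that the two steps differ, not why they differ or how the change would behave on any further core.

Still open, from the compounds shown here alone, is which part of the difference between the core of compound 1 and the core of compound 2 goes with the gap, as the two cores are not broken down into single changes here. Also open, going by these compounds, is how a longer chain on the ester, or a carboxylic acid or an amide in its place, would behave on each of the two cores.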